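The compounds below may be only part of what the source reports. "The series", "measured", "known", "first", "only" and "open" are said of these compounds alone.

Three compounds have been measured in a functional assay on COLO 205 cells (Homo sapiens) for cytotoxicity; on this read-out higher numbers stand for weaker inhibition and lower numbers for stronger inhibition:

Compound 1, `Cc1ccc(S(=O)(=O)/N=C(\S)Nc2ccc(Cl)cc2)cc1`, gives 87 ug/mL.
Compound 2, `Cc1c(S(=O)(=O)/N=C(\S)Nc2ccc(Cl)cc2)sc2ccc(Cl)cc12`, gives 52 ug/mL.
Compound 3, `Cc1ccc(S(=O)(=O)/N=C(\S)Nc2ccc(Cl)c(Cl)c2)cc1`, gives 45 ug/mL.

Compound 3 differs from compound 1 by one change, (chloro in place of hydrogen on an aromatic carbon). That change gave a 1.9-fold lower number from compound 1 to compound 3 (0.29 log units; within the scatter). Compound 2 shares the same right-hand part as compound 1 but carries a different core; how the two cores differ is not broken down here. In this assay the values of compound 2 and compound 1, and of compound 2 and compound 3, lie within the scatter of one another, so no ordering among the three can be read from them.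

Compound 4, `Cc1c(S(=O)(=O)/N=C(\S)Nc2ccc(Cl)c(Cl)c2)sc2ccc(Cl)cc12`, is not yet measured. It stands to compound 2 as compound 3 stands to compound 1: the difference is chloro in place of hydrogen on an aromatic carbon, at a place described in the same words as before, so it is the same change on a different core. Because the earlier step was a 1.9-fold lower number from compound 1 to compound 3 (0.29 log units; within the scatter), the step from compound 2 to compound 4 in this assay is expected to be about as small, a 1.6-fold lower number from compound 2 to compound 4 (0.20 log units; within the scatter). Compound 4 is therefore estimated at 33 ug/mL, with a range from 15 ug/mL to 75 ug/mL.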

Compound 4, half-maximal inhibitory concentration: 57 ug/mL
Beside the measured number, compound 4's estimate is 1.7-fold (0.24 log units) below it; the measured number falls inside the stated range.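

In this assay, going from 4-chlorophenyl to 3,4-dichlorophenyl on the second core gave a 1.1-fold higher number from compound 2 to compound 4 (0.04 log units; within the scatter). Set beside the same change on the first core, the two steps cannot be told apart: the same change on two cores in this assay, a 1.9-fold lower number (0.29 log units; within the scatter) from compound 1 to compound 3 and a 1.1-fold higher number (0.04 log units; within the scatter) from compound 2 to compound 4, 2.1-fold (0.33 log units) apart, within the scatter of two such steps. This means the series gives no sign that the core alters the effect of this chloro, but it does not prove that the effect carries over unchanged, as both steps are small enough to lie within the scatter and a modest real difference could go unseen.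

The compounds shown carry only hydrogen or chloro at this place on the ring, so it remains open whether a methoxy group, a trifluoromethyl group, an amine or a carboxylic acid there would give a step beyond the scatter on either core. From the compounds shown here alone, whether such a larger step would carry from one core to the other also remains open.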